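Replacing the triazolyl group of compound 3 with benzamido

A few compounds are considered here, and "the series" means these few. Any claim that something is new, unique, unknown or untested is made for them only; others in the source may bear on it.

The series shares one core carrying a sulfonamide, a chlorine and a benzylthio group. In a functional assay on MCF7 cells (Homo sapiens) for cytotoxicity, read by MTT assay, with a stated time of 72 h (on this read-out lower numbers stand for stronger inhibition and higher numbers for weaker inhibition), compound 1 `[N-]=[N+]=NCc1nnc(-c2cc(S(N)(=O)=O)c(SCc3ccccc3)cc2Cl)o1` gives 55000 nM, compound 2 `CCOC(=O)c1cn(Cc2nnc(-c3cc(S(N)(=O)=O)c(SCc4ccccc4)cc3Cl)o2)nn1` gives 150000 nM and compound 3 `CC(C)(O)c1cn(Cc2nnc(-c3cc(S(N)(=O)=O)c(SCc4ccccc4)cc3Cl)o2)nn1` gives 168000 nM, the highest of the three numbers; its nearest neighbour is compound 2, within the scatter, while compound 1 sits furthest away. The two steps from the azido parent, a 2.7-fold higher number from compound 1 to compound 2 (0.44 log units; beyond the scatter) and a 3.1-fold higher number from compound 1 to compound 3 (0.48 log units; beyond the scatter), were modest and both beyond the scatter, whereas the step of a 1.1-fold higher number from compound 2 to compound 3 (0.05 log units; within the scatter) stayed within it.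

Compound 4 `NS(=O)(=O)c1cc(-c2nnc(CNC(=O)c3ccccc3)o2)c(Cl)cc1SCc1ccccc1` differs from compound 3 by benzamido in place of 4-(1-hydroxy-1-methylethyl)-1H-1,2,3-triazol-1-yl on a saturated chain carbon bound to an aromatic carbon. Among the compounds with values here, no measured step removes the triazolyl group, so the bearing of the earlier steps is indirect: swapping the group on that chain carbon moved this assay by modest amounts at most. Compound 4 is therefore expected to show a 1.9-fold lower number from compound 3 to compound 4 (0.27 log units; within the scatter), a small change toward lower numbers or none beyond the scatter. The estimate for compound 4 in this assay is 90000 nM, between 30000 nM and 250000 nM.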

Compound 4, half-maximal inhibitory concentration: 66000 nM
The estimate for compound 4 lay 1.4-fold (0.13 log units) above the measured number; the measured number falls inside the stated range.
By their numbers in this assay, from the lowest: compounds 1 and 4 (each within the scatter of the next); then compounds 2 and 3 (each within the scatter of the next).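

In this assay, benzamido is the only replacement for azido on the saturated chain carbon that stays level with the azido parent, a 1.2-fold higher number from compound 1 to compound 4 (0.08 log units; within the scatter), while the triazolyl compounds stand apart from it, with a 2.5-fold lower number from compound 3 to compound 4 (0.41 log units; beyond the scatter) and a 2.3-fold lower number from compound 2 to compound 4 (0.36 log units; beyond the scatter) as the two steps. Benzamido and 4-(1-hydroxy-1-methylethyl)-1H-1,2,3-triazol-1-yl carry the same heavy-atom count yet differ beyond the scatter, so among these compounds that count alone does not set the number at this position. No measurement is available that would account for this difference.

From the compounds shown here alone, how an amine, an acetamido group or a carboxylic acid on that chain carbon would read in this assay remains open. So does the question of whether the amide or the benzene ring of benzamido matters more for the step away from the triazolyl compounds.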